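This account rests on a few compounds, and the source may have more. Where it says the series, first, only, none or still open, it means among the compounds named here.

Measured so far in a functional assay on Ehrlich cells (Mus musculus) for cytotoxicity, read by trypan blue exclusion, with a stated time of 2 h, tested at 25 ug/mL; on this read-out higher numbers stand for a stronger effect at the one concentration tested and lower numbers for a weaker effect:
compound 1, `N#CC1=C(N)N(c2ccc(S(N)(=O)=O)cc2)C2=C(C(=O)CCC2)C1c1ccc(Cl)cc1Cl` — 50%
compound 2, `N#CC1=C(NC(=O)/C=C/c2ccccc2)N(c2ccc(S(N)(=O)=O)cc2)C2=C(C(=O)CCC2)C1c1ccc(Cl)cc1Cl` — 30%

Compound 2 gives the lowest of the two numbers in this assay; its nearest neighbour is compound 1, and the step of a number 20 percentage points lower from compound 1 to compound 2 (beyond the scatter) lies beyond the scatter. Among the compounds with values here, that step replaced hydrogen on an amine nitrogen with (2-phenylethenyl)carbonyl, and it is the only measured step that bears on compound 3, `N#CC1=C(NC(=O)c2ccc([N+](=O)[O-])cc2)N(c2ccc(S(N)(=O)=O)cc2)C2=C(C(=O)CCC2)C1c1ccc(Cl)cc1Cl`, which is not yet measured.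

Compound 3 differs from compound 2 by 4-nitrophenyl in place of 2-phenylethenyl on a carbonyl carbon. Within the data shown here, the measured step speaks only to the presence of a carbonyl group on that nitrogen, not to what is attached to the carbonyl carbon; no measured pair tells how exchanging (2-phenylethenyl)carbonyl for (4-nitrophenyl)carbonyl shifts the read-out. Among the measured compounds shown here, the account therefore expects no step beyond the scatter in this assay for compound 3, with the uncertainty widened because the exchange itself has no precedent among the measured compounds.

Compound 3 is expected to give 30% in this assay, with a likely range from 15% to 50%, a step of no change at the digits printed from compound 2 to compound 3 (within the scatter) as estimated.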

Compound 3, a percentage reported as activity, at one concentration (the size of the read-out at that concentration, not a potency): 40%
Compound 3: the middle estimate sits 10 percentage points below what was measured; the range from low to high includes it.
By their numbers in this assay, from the lowest: compounds 2, 3 and 1 (each within the scatter of the next, the first and the last beyond it).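

In this assay the exchange of 2-phenylethenyl for 4-nitrophenyl on the carbonyl carbon gives a number 10 percentage points higher from compound 2 to compound 3 (within the scatter) and so, at this place, the read-out does not tell these two groups apart. The earlier change on the amine nitrogen, (2-phenylethenyl)carbonyl in place of hydrogen, gave a number 20 percentage points lower from compound 1 to compound 2 (beyond the scatter) whereas (4-nitrophenyl)carbonyl in place of hydrogen gives a number 10 percentage points lower from compound 1 to compound 3 (within the scatter) and so a step beyond the scatter does not accompany every carbonyl group placed on that nitrogen, and compound 3 cannot be ordered against either of the other two. Nothing among the available data accounts for these results.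

The compounds shown leave open whether a carbonyl group carrying no aromatic ring, such as acetyl, or a longer alkyl chain, would stay within the scatter of compound 1 or fall beyond it. They also leave open whether an amine or a methoxy group in place of the nitro group on the phenyl ring would move the read-out, and how any of these compounds would behave at a concentration other than the one tested.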